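A few compounds are considered here, and "the series" means these few. Any claim that something is new, unique, unknown or untested is made for them only; others in the source may bear on it.

Measured in a functional assay on PC-3 cells (Homo sapiens) for antiproliferative activity, read by MTT assay, with a stated time of 72 h; on this read-out higher numbers stand for weaker inhibition and lower numbers for stronger inhibition:
- compound 1 `O=C(N/N=C/c1ccccc1)Nc1ccc(Oc2ccnc3[nH]ccc23)c(F)c1`: 7940 nM
- compound 2 `O=C(N/N=C/c1ccc(F)cc1)Nc1ccc(Oc2ccnc3[nH]ccc23)c(F)c1`: 2330 nM
- compound 3 `O=C(N/N=C/c1cccc(Cl)c1Cl)Nc1ccc(Oc2ccnc3[nH]ccc23)c(F)c1`: "not active" (no number reported)

Compound 2 holds the lower of the two numbers, while compound 3 gave no number and so offers no step size. Compound 4 `O=C(N/N=C/c1ccc(O)cc1)Nc1ccc(Oc2ccnc3[nH]ccc23)c(F)c1` differs from compound 2 as follows: hydroxy in place of fluoro on an aromatic carbon. Among the measured compounds shown here, no hydroxy compound has been measured, so the only guide is a 3.4-fold lower number from compound 1 to compound 2 (0.53 log units; beyond the scatter), a modest step with fluoro in place of hydrogen on an aromatic carbon. With the fluoro gone, a partial return towards compound 1 at 7940 nM is expected, meaning a higher number in this assay. The expected change is a 1.9-fold higher number from compound 2 to compound 4 (0.29 log units; within the scatter). For compound 4 the estimate is 4500 nM, with an expected range from 1500 nM to 14000 nM.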

Compound 4, half-maximal inhibitory concentration: 2780 nM
Compound 4: middle estimate off by 1.6-fold (0.21 log units), on the high side; low and high end bracket the measured number.
By their numbers in this assay, from the lowest: compounds 2 and 4 (each within the scatter of the next); then compound 1.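

In this assay, hydroxy in place of fluoro at this position gives a 1.2-fold higher number from compound 2 to compound 4 (0.08 log units; within the scatter), so the data do not separate these two groups here. Hydroxy in place of hydrogen gives a 2.9-fold lower number from compound 1 to compound 4 (0.46 log units; beyond the scatter), which shows that fluoro is not the only group at this position to give a step beyond the scatter from compound 1. Nothing measured here gives a reason for either step. As far as these compounds go, whether an amine, a methoxy group or a carboxylic acid in the same position would give a similar number remains open.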